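The compounds below may be only part of what the source reports. "The series", "measured", "known", "first", "only" and "open" are said of these compounds alone.

Series notes. Compound 1 `NC(=O)c1c(NC(=O)c2ccccc2Cl)sc2c1CCN(Cc1c(Cl)cccc1Cl)C2` and compound 2 `NC(=O)c1c(NC(=O)c2ccccc2F)sc2c1CCN(Cc1c(Cl)cccc1Cl)C2` share one core; compound 3 `NC(=O)c1c(NC(=O)c2ccccc2Br)sc2c1CCN(C(=S)Nc1ccccc1Cl)C2` and compound 4 `NC(=O)c1c(NC(=O)c2ccccc2Br)sc2c1CCN(C(=S)Nc1ccccc1F)C2` share another, and the difference between the two cores is not broken down here.

In a functional assay on HeLa cells (Homo sapiens) for antiproliferative activity, with a stated time of 24 h (a higher number here means a weaker inhibitor, a lower number a stronger inhibitor), compound 1 gives 28800 nM. In the same assay compound 2 gives 33000 nM. The change between them, (fluoro in place of chloro on an aromatic carbon), produced a 1.1-fold higher number from compound 1 to compound 2 (0.06 log units; within the scatter). Compound 3 gives 46900 nM; its gaps to compound 1 and compound 2 are within the scatter, so no ordering among the three is claimed.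

Compound 4 carries the change fluoro in place of chloro on an aromatic carbon on the second core. Its place line matches that of the earlier change word for word, so it is taken as the same change, here on the (2-chlorophenyl)amino part rather than on the ((2-chlorophenyl)carbonyl)amino part. Going by the values given here, since the only precedent, from compound 1 to compound 2, is a 1.1-fold higher number from compound 1 to compound 2 (0.06 log units; within the scatter), a step of about the same size is expected from compound 3 to compound 4, namely a 1.1-fold higher number from compound 3 to compound 4 (0.03 log units; within the scatter). On that basis compound 4 is estimated at 50000 nM, with a range from 25000 nM to 100000 nM in this assay.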

Compound 4, half-maximal inhibitory concentration: > 50000 nM
Compound 4 ended at the assay's limit; the forecaster's own chance of this, stated with the estimate: 15%; the middle value lies on the limit itself.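

In this assay compound 4 gives > 50000 nM, a limit of the assay and not a number. Fluoro in place of chloro on an aromatic carbon, carried to the second core, reads as an at least 1.0-fold higher number from compound 3 to compound 4 (0.02 log units; that floor lies within the scatter); this is a floor, so the result is compatible with a similar small step on both cores but does not show that the change transfers unaltered: the same change on two cores in this assay, a 1.1-fold higher number (0.06 log units; within the scatter) from compound 1 to compound 2 and an at least 1.0-fold higher number (0.02 log units; that floor lies within the scatter) from compound 3 to compound 4; the limit leaves it open whether they differ The true distance of compound 4 from compound 3 stays unknown, and a larger step on this core is not excluded, with the only reading resting on: the limit of > 50000 nM in this assay, at which 1 of the 4 values shown sits.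

The two steps also sit on different parts of their molecules, the ((2-chlorophenyl)carbonyl)amino part in compound 1 and the (2-chlorophenyl)amino part in compound 3, so the part carrying the change and the core cannot be told apart. Open too, on these data alone, is how a group other than a halogen, such as a methoxy, an amine or a carboxylic acid, would read in place of chloro on either part.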